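The source may report more compounds than this note shows. Statements on the series, on what has been measured and on what is new or still open speak of the compounds shown alone.

Series notes: two spiro compounds have been measured in a functional assay on COLO 205 cells (Homo sapiens) for cytotoxicity, read by MTT assay, with a stated time of 24 h (a lower number here means a stronger inhibitor, a higher number a weaker inhibitor), so far. Compound 1, `CCCc1nn(C)c2c1NC1(CCCCC1)NC2=O`, gives 18000 nM in this assay. Compound 2, `CCN1C(=O)C2(NC(=O)c3c(sc4c3CCCC4)N2)c2ccccc21`, gives 12000 nM in this assay, the lower of the two numbers, though compound 1 lies within the scatter of it, so no order between the two can be read. Among the measured compounds shown here, no pair that differs in one place has been measured, so the effect of a single change on this read-out is not yet known.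

The next compound is compound 3, `CC(C)N1C(=O)C2(NC(=O)c3c(sc4c3CCCC4)N2)c2ccccc21`. It differs from compound 2 by methyl in place of hydrogen on a saturated chain carbon bound to an amide-type nitrogen in a ring and a saturated chain carbon. Compound 3 is expected to give a value close to that of compound 2, with a step of a 1.1-fold lower number from compound 2 to compound 3 (0.04 log units; within the scatter) that should not exceed the scatter in either direction, since nothing in the two measured values points to a larger effect. Compound 3 is estimated at 11000 nM, within a range of 4000 nM to 30000 nM.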

Compound 3, half-maximal inhibitory concentration: 6000 nM
Compound 3: middle estimate off by 1.8-fold (0.26 log units), on the high side; the range from low to high includes it.
By their numbers in this assay, from the lowest: compounds 3, 2 and 1 (each within the scatter of the next, the first and the last beyond it).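

In this assay, the change from ethyl to isopropyl, with methyl in place of hydrogen on a saturated chain carbon bound to an amide-type nitrogen in a ring and a saturated chain carbon, gives a 2.0-fold lower number from compound 2 to compound 3 (0.30 log units; within the scatter). Among the compounds shown here, this is the first pair that differs in one place, and it shows that this single methyl at this position does not carry the read-out beyond the scatter, so no gain can be claimed for isopropyl over ethyl from this pair alone. For the compounds shown here, nothing measured so far offers an account of this small step.

Still open, going by these compounds, is whether a longer chain such as butyl, a benzyl group or a chain ending in an amine, in place of the isopropyl, would shift the number beyond the scatter. Also open, on these data alone, is whether a carboxylic acid on that chain would do so.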